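Dichlorobenzyl ethers: removing one chloro, cytotoxicity on macrophages

A few compounds are considered here, and "the series" means these few. Any claim that something is new, unique, unknown or untested is made for them only; others in the source may bear on it.

Four ethers are compared, all carrying a chlorinated benzyl ether joined to a side chain that ends in an azole. Compound 1 `Clc1ccc(Cl)c(COC(CCn2cncn2)c2cccs2)c1` has no result in an ADME assay on J774.A1 cells (Mus musculus) for cytotoxicity, read by MTT assay, with a stated time of 72 h; on this read-out lower numbers stand for higher toxicity in this test and higher numbers for lower toxicity in this test: its entry reads "not determined" (no result reported). Compound 2 `Clc1ccc(Cl)c(COC(CCn2ccnc2)c2ccco2)c1` and compound 3 `Clc1cccc(COC(CCn2ccnc2)c2ccco2)c1` differ from compound 1 in their core, and the difference between the two cores is not broken down here. Compound 4 `Clc1cccc(COC(CCn2cncn2)c2cccs2)c1` is not yet measured.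

In this assay compound 2 gives 37600 nM and compound 3 gives 60200 nM. Within the data shown here, the step of a 1.6-fold higher number from compound 2 to compound 3 (0.20 log units; within the scatter) is the only measured step in the set; the change is hydrogen in place of chloro on an aromatic carbon. The same change, (hydrogen in place of chloro on an aromatic carbon), is made from compound 1 to compound 4, and its place line matches word for word.

No number for compound 1 exists, so the expectation for compound 4 cannot be built as a step from compound 1. It rests on the two measured compounds alone: compound 2 with 37600 nM and compound 3 with 60200 nM sit within the scatter of each other after the same change, so the change itself is not expected to move the number beyond the scatter, and compound 4 is expected to fall in the region where compound 2 and compound 3 sit.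

Compound 4 is estimated to give about 50000 nM in this assay, with an expected range from 20000 nM to 130000 nM.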

Compound 4, half-maximal cytotoxic concentration: 15600 nM
For compound 4 the middle estimate is 3.2-fold (0.51 log units) above the measured one; the whole stated range lies above it.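

In this assay, among these compounds, compound 1 reads "not determined" (no result reported) and so no step from compound 1 to compound 4 can be read. The compounds shown leave open how hydrogen in place of chloro acts on the core of compound 1, and how that core compares with the core of compound 2. Nothing shown offers an explanation for the value of compound 4.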